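Sulfanyl to sulfonyl: notes on compound 2 and compound 4

This account rests on a few compounds, and the source may have more. Where it says the series, first, only, none or still open, it means among the compounds named here.

Three compounds of the shared core have been run in an assay on CHO cells for binding affinity to Alpha-2C adrenergic receptor (Homo sapiens), read by radioligand binding; on this read-out higher numbers stand for weaker inhibition and lower numbers for stronger inhibition. Compound 2 `CSc1ccc(C)cc1NCC1=NCCN1` gives 200 nM, the lower of the two numbers read out. Compound 3 `CS(=O)(=O)c1cccc(F)c1NCC1=NCCN1` gives 692 nM, a higher number that lies beyond the scatter of repeated measurements. Compound 1 `COc1ccc(S(C)(=O)=O)c(NCC2=NCCN2)c1` returns only a limit of the assay, < 5020 nM, and no number; this is what the limit of < 5020 nM in this assay, at which 1 of the 3 values shown sits, records. Compound 4 `Cc1ccc(S(C)(=O)=O)c(NCC2=NCCN2)c1` has not yet been measured in this assay.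

The change from compound 2 to compound 4 is methylsulfonyl in place of methylsulfanyl on an aromatic carbon. Going by the values given here, no measured pair differs in exactly this way, so no step of this kind is in hand. Two compounds that already carry methylsulfonyl are in hand. Compound 3 gives 692 nM, on the weaker side of what is known. Compound 1 returns only a limit of the assay. This is all the data offer as guidance for the new compound.

The step expected in this assay from compound 2 to compound 4 is a 5.0-fold higher number from compound 2 to compound 4 (0.70 log units; beyond the scatter), toward a higher number and beyond the scatter. Compound 4 is estimated at 1000 nM in this assay, with a range from 300 nM to 4000 nM.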

Compound 4, inhibition constant: < 5020 nM
Compound 4: no number, only a limit; the forecaster's own chance of this, stated with the estimate: 15%; the middle value is on the limit's open side.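

In this assay compound 4 gives < 5020 nM, which is a limit of the assay and not a number. Going by these compounds alone, no step can therefore be read from compound 2 or compound 1 to compound 4. The compounds shown leave open how far methylsulfonyl in place of methylsulfanyl on an aromatic carbon shifts the read-out, and how compound 1 and compound 4 compare.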